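The source may report more compounds than this note shows. Statements on the series, on what has been measured and on what is new or still open speak of the compounds shown alone.

Measured compounds:
compound 1 `CC(C)S(=O)(=O)c1ccc(S(=O)(=O)N2CCC[C@@H](C(=O)N3CCC(F)(F)CC3)C2)cc1`, with 9.1 nM in a functional assay on MIA PaCa-2 cells (Homo sapiens) for inhibition, read by MTT assay, with a stated time of 3 days; a higher number here means a weaker inhibitor, a lower number a stronger inhibitor
compound 2 `CCN(CC)S(=O)(=O)c1ccc(S(=O)(=O)N2CCC[C@@H](C(=O)N[C@H]3CC[C@@H](OC)CC3)C2)cc1`, with 590 nM in this assay

Compound 2 stands highest of the two numbers in this assay; its nearest neighbour is compound 1, whose number is far lower, a gap beyond the scatter. Compound 3 `CCN(CC)S(=O)(=O)c1ccc(S(=O)(=O)N2CCC[C@@H](C(=O)N3CCC(F)(F)CC3)C2)cc1` is not yet measured. It differs from compound 2 in one place: 4,4-difluoropiperidin-1-yl in place of (4-methoxycyclohexyl)amino on a carbonyl carbon. Among the compounds with values here, the amide of compound 3 is therefore the one carried by compound 1, while its sulfonyl part remains that of compound 2. Within the data shown here, no step between two measured compounds isolates this change, so the expectation rests on the two values alone. Because compound 1 gives 9.1 nM with the difluoropiperidine amide, compound 3 is expected to move towards that number, a step downward beyond the scatter, a 17-fold lower number from compound 2 to compound 3 (1.23 log units; beyond the scatter). Compound 3 is estimated at 35 nM, within a range of 8 nM to 160 nM.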

Compound 3, half-maximal inhibitory concentration: 19 nM
Estimate against measurement, compound 3: 1.8-fold (0.27 log units) above; the measured number falls inside the stated range.
By their numbers in this assay, from the lowest: compound 1; then compound 3; then compound 2.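

With the diethylamino group on the sulfonyl sulfur held constant, the amide change alone gives a 31-fold lower number from compound 2 to compound 3 (1.49 log units; beyond the scatter) in this assay, showing that the group on this carbonyl carbon has a large effect on the number, which the two earlier compounds, differing in two places, could not show. With the 4,4-difluoropiperidin-1-yl amide held constant, the change on the sulfonyl sulfur gives a 2.1-fold higher number from compound 1 to compound 3 (0.32 log units; beyond the scatter), a modest step that is beyond the scatter and smaller than the amide step. Nothing available explains either step.

The compounds shown leave open whether the amide step keeps its size with isopropyl on the sulfonyl sulfur. They also do not tell how much of it belongs to the fluorine atoms, a question that a plain piperidin-1-yl amide would address.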